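A few compounds are considered here, and "the series" means these few. Any claim that something is new, unique, unknown or untested is made for them only; others in the source may bear on it.

Measured in a functional assay on CHO cells for agonist activity at Free fatty acid receptor 1 (Homo sapiens), read by calcium flux; a higher number here means that more compound is needed for the effect, a lower number that less compound is needed:

compound 1 `O=C(O)CCc1nnc(C(=O)Nc2cccc(-c3cccc(Cl)c3)c2)s1` gives 1690 nM
compound 2 `O=C(O)CCc1nnc(C(=O)Nc2ccc(OCc3ccccc3)cc2)s1` gives 17900 nM
compound 3 `O=C(O)CCc1ccc(OCc2nnc(C(=O)Nc3ccc(F)cc3)s2)cc1` gives 6640 nM

Compound 3 stands second highest of the three numbers in this assay; its nearest neighbour is compound 2, whose number lies higher by more than the scatter, and compound 1 sits lowest, below compound 3 by a gap that is also beyond the scatter. No pair among these three differs in only one place, so no single-point step is available.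

Compound 4 `O=C(O)CCc1ccc(OCc2nnc(C(=O)Nc3ccc(F)c(F)c3)s2)cc1` differs from compound 3 by fluoro in place of hydrogen on an aromatic carbon. Within the data shown here, with no matching step among the measured compounds, the change from compound 3 to compound 4 is expected to be small, a 1.2-fold lower number from compound 3 to compound 4 (0.08 log units; within the scatter), not clearly beyond the scatter in either direction. Compound 4 is estimated at 5500 nM, within 2500 nM to 12000 nM.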

Compound 4, half-maximal effective concentration: 580 nM
Compound 4: the middle estimate sits 9.5-fold (0.98 log units) above what was measured, outside the stated range (below it).
By their numbers in this assay, from the lowest: compound 4; then compound 1; then compound 3; then compound 2.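

In this assay the change from 4-fluorophenyl to 3,4-difluorophenyl gives an 11-fold lower number from compound 3 to compound 4 (1.06 log units; beyond the scatter) and so shows that a single fluoro at this aromatic carbon, ortho to a fluoro group, can shift the number markedly. Among these compounds, the earlier compounds offered no single-place step, so this is the first direct reading of one position. Nothing at hand accounts for the size of this step.

Open, on these data alone, is whether chloro or methoxy in the same place would give a step of similar size. Also open, as far as these compounds go, is whether the step needs the existing fluoro group or carries over to the core of compound 1.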